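Chain variation at the ring nitrogen of the shared core

A few compounds are considered here, and "the series" means these few. Any claim that something is new, unique, unknown or untested is made for them only; others in the source may bear on it.

Measured so far:
compound 1 `Cn1cnc2c1c(=O)n(CC(=O)O)c(=O)n2C` — in an assay on HEK293 cells for binding affinity to adenosine receptor A2b (Homo sapiens), read by radioligand binding (on this read-out higher numbers stand for weaker inhibition and lower numbers for stronger inhibition), compound 1 gives 23500 nM
compound 2 `CC(=O)OCCn1c(=O)c2c(ncn2C)n(C)c1=O` — in this assay compound 2 gives 8710 nM

Among the compounds with values here, on the numbers in hand, compound 2 stands lowest of the two; its only neighbour is compound 1, and the single measured step, a 2.7-fold lower number from compound 1 to compound 2 (0.43 log units; beyond the scatter), is a modest one at the chain on the saturated chain carbon bound to an aromatic nitrogen.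

Compound 3 `CC(=O)Cn1c(=O)c2c(ncn2C)n(C)c1=O` is the next member of the series and differs from compound 2 by acetyl in place of acetoxymethyl on a saturated chain carbon bound to an aromatic nitrogen. Within the data shown here, the same position was altered in the one measured step, a 2.7-fold lower number from compound 1 to compound 2 (0.43 log units; beyond the scatter), which is the only comparison that bears on the new change; nothing measured shows an acetyl at this place. Given that the one known step at this position was modest, the expected step for compound 3 in this assay is small, most likely not beyond the scatter, with no firm direction. Compound 3 is therefore estimated at 8000 nM, with a range from 3000 nM to 25000 nM, which means an expected step of a 1.1-fold lower number from compound 2 to compound 3 (0.04 log units; within the scatter).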

Compound 3, inhibition constant: 20800 nM
The estimate for compound 3 lay 2.6-fold (0.41 log units) below the measured number, within the range that was stated.
By their numbers in this assay, from the lowest: compound 2; then compounds 3 and 1 (each within the scatter of the next).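

The change from acetoxymethyl to acetyl shows that this position on the saturated chain carbon bound to an aromatic nitrogen does respond to a neutral change of group in this assay, with a 2.4-fold higher number from compound 2 to compound 3 (0.38 log units; beyond the scatter), so the 2-acetoxyethyl chain of compound 2 stands apart from the 2-oxopropyl chain of compound 3. Methyl in place of hydroxy on the carbonyl carbon, by contrast, gives a 1.1-fold lower number from compound 1 to compound 3 (0.05 log units; within the scatter), which leaves compound 1 and compound 3 unseparated and makes compound 2 the only one of the three whose number stands clear of both others. No measurement at hand offers an explanation for either step.

Acetoxymethyl and acetyl differ at once in heavy atoms and in hydrogen-bond acceptors, so the series does not yet tell whether the lower number of compound 2 goes with the ester link, with the length of the chain or with both. Open too, from the compounds shown here alone, is how this position would take an amine, an amide or a longer ester chain such as a propionyloxy group on the same carbon.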